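The source may report more compounds than this note shows. Statements on the series, on what has been measured and on what is new or still open speak of the compounds shown alone.

Measured compounds in a functional assay on the whole organism (Tail, strain ICR) with Mus musculus as the target, in the tail flick test, with a stated time of 90 min, at a dose of 25 umol/kg by the oral route; on this read-out lower numbers stand for a weaker effect and higher numbers for a stronger effect at the one dose given:
- compound 1 `CC(C)[C@H](NC(=O)CN(c1nc(Cl)nc2[nH]cnc12)C1CC1)C(=O)OCc1ccccc1` gives 51.3%
- compound 2 `O=C(CN(c1ncnc2c1ncn2C1CCCCO1)C1CC1)NCC(=O)OCc1ccccc1` gives 25.9%
- compound 3 `C[C@@H](O)[C@H](NC(=O)CN(c1nc(Cl)nc2[nH]cnc12)C1CC1)C(=O)O` gives 35.9%

Compound 2 stands lowest of the three numbers in this assay. Its nearest neighbour is compound 3, whose number lies within the scatter of the number for compound 2, so no order between these two can be read. Compound 1 gives the furthest number, and that gap is beyond the scatter, so compound 1 stands stronger than compound 2.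

Compound 4 `C[C@H](NC(=O)CN(c1ncnc2c1ncn2C1CCCCO1)C1CC1)C(=O)OCc1ccccc1` is not yet measured. Relative to compound 2 it differs by methyl in place of hydrogen on a saturated chain carbon bound to an amide-type nitrogen and a carbonyl carbon. Among the compounds with values here, no pair of measured compounds differs in one place, so no comparable step is recorded. The change is a single carbon, and a step of this kind is expected to stay within the scatter, if anything leaning upward, as compound 1 and compound 3 with larger groups at that carbon both give higher numbers than compound 2 in this assay.

Compound 4 is therefore estimated at 32%, with a range from 15% to 50%. This estimate means an expected step of a number 6.1 percentage points higher from compound 2 to compound 4 (within the scatter), which is not beyond the scatter.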

Compound 4, a percentage reported as activity, at one dose (the size of the read-out at that dose, not a potency): 32.1%
For compound 4 the middle estimate is 0.1 percentage points below the measured one, within the range that was stated.
By their numbers in this assay, from the lowest: compounds 2, 4 and 3 (each within the scatter of the next); then compound 1.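

In this assay, within the data shown here, methyl in place of hydrogen on a saturated chain carbon bound to an amide-type nitrogen and a carbonyl carbon gives a number 6.2 percentage points higher from compound 2 to compound 4 (within the scatter) as the first one-place step. Among these compounds, at this position, then, a single methyl leaves the read-out indistinguishable from that of the hydrogen compound, which the earlier compounds, differing from one another in more than one place, could not show. No available measurement bears on the reason for the size of this step.

From the compounds shown here alone, whether a larger group at this carbon, such as a benzyl group or a longer chain ending in an amine, would give a step beyond the scatter remains open. The opposite configuration of the methyl at this carbon is also left open.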